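A few compounds are considered here, and "the series" means these few. Any claim that something is new, unique, unknown or untested is made for them only; others in the source may bear on it.

Measured in a functional assay on MV4-11 cells (Homo sapiens) for antiproliferative activity, read by resazurin assay, with a stated time of 72 h; on this read-out higher numbers stand for weaker inhibition of growth and lower numbers for stronger inhibition of growth:
- compound 1 `CC(=O)N1CCN(c2ccc(Nc3nccc(-c4c[nH]c5ccccc45)n3)cc2)CC1`: 33 nM
- compound 2 `CC(=O)N1CCCN(c2cccc(Nc3nccc(-c4c[nH]c5cccnc45)n3)c2)CC1`: 688 nM
- compound 3 `CC(=O)N1CCN(c2ccc(Nc3ncc(C#N)c(-c4c[nH]c5ccccc45)n3)cc2)CC1`: 4 nM

Compound 3 has the lowest number of the three, so it shows the strongest inhibition of growth. Compound 4 `CC(=O)N1CCN(c2ccc(Nc3ncc(C#N)c(-c4c(C)[nH]c5ccccc45)n3)cc2)CC1` differs from it in one place: methyl in place of hydrogen on an aromatic carbon. This puts methyl in place of hydrogen on an aromatic carbon.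

Going by the values given here, only one measured step bears on this, an 8.3-fold lower number from compound 1 to compound 3 (0.92 log units; beyond the scatter). That step was a cyano in place of hydrogen on an aromatic carbon, so it shows that a single small change on this core can shift the number, but it does not involve a methyl. Among the compounds with values here, with no measured step for this methyl, only a small change is expected in this assay. The expected step is a 1.8-fold higher number from compound 3 to compound 4 (0.24 log units; within the scatter), toward a slightly higher number. The estimate for compound 4 is 7 nM, with an expected range of 1.5 nM to 30 nM.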

Compound 4, concentration for 50% growth inhibition: 390 nM
Compound 4: the middle estimate sits 56-fold (1.75 log units) below what was measured, outside the stated range (above it).
By their numbers in this assay, from the lowest: compound 3; then compound 1; then compounds 4 and 2 (each within the scatter of the next).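

In this assay the step of a 98-fold higher number from compound 3 to compound 4 (1.99 log units; beyond the scatter) shows that this carbon of the five-membered aromatic ring, next to the ring nitrogen, tolerates even one added methyl poorly. This single carbon moves the number further than the earlier 8.3-fold lower number from compound 1 to compound 3 (0.92 log units; beyond the scatter) did, and in the opposite direction. Nothing shown here explains the loss. Still open, going by these compounds, is whether a fluorine, a chlorine or an ethyl at this carbon would cost as much, and whether the methyl would do the same on compound 1, which has no nitrile.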